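This account rests on a few compounds, and the source may have more. Where it says the series, first, only, none or still open, it means among the compounds named here.

Measured compounds in an ADME assay on THP-1 cells (Homo sapiens) for cytotoxicity, read by resazurin assay, with a stated time of 72 h; a higher number here means that more compound is tolerated, a lower number that less compound is tolerated:
- compound 1 `O=C(/C=C/c1ccc([N+](=O)[O-])o1)c1ccc(I)cc1`: 49500 nM
- compound 2 `O=C(/C=C/c1cccc([N+](=O)[O-])c1)c1ccc(N2CCCCC2)cc1`: in this assay compound 2 gives > 50000 nM, which is a limit of the assay and not a number
- compound 3 `O=C(/C=C/c1ccc([N+](=O)[O-])o1)c1cccc(Br)c1`: 14900 nM

Compound 1 stands highest of the two numbers shown. Compound 3 gives a lower number, and the gap between compound 1 and compound 3 lies beyond the usual scatter. The value for compound 2 sits at the limit of > 50000 nM in this assay, at which 1 of the 3 values shown sits; it is read only as a limit and is not ordered against the two numbers.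

Among the compounds with values here, no step between measured compounds shares a single change, so the step to compound 4 `O=C(/C=C/c1ccc([N+](=O)[O-])o1)c1ccc(-c2ccccc2)cc1` is read from the structures alone. The change is phenyl in place of iodo on an aromatic carbon of the six-membered aromatic ring of carbon only, para to a large group. The nitrofuran side and the enone of the shared core of compound 1 are kept.

With nothing measured on this change, the expectation is a small step in this assay, if any, and the direction is uncertain; a move toward a lower number, as from compound 1 to compound 3, cannot be ruled out. The estimated step is a 1.7-fold lower number from compound 1 to compound 4 (0.22 log units; within the scatter). For compound 4 the estimate in this assay is 30000 nM, expected between 8000 nM and 60000 nM.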

Compound 4, half-maximal cytotoxic concentration: 50400 nM
The estimate for compound 4 lay 1.7-fold (0.23 log units) below the measured number, within the range that was stated.
By their numbers in this assay, from the lowest: compound 3; then compounds 1 and 4 (each within the scatter of the next).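

Within the data shown here, the only single-change step is phenyl in place of iodo on an aromatic carbon, para to a large group, and in this assay it reads a 1.0-fold higher number from compound 1 to compound 4 (0.01 log units; within the scatter). At this place on the shared core, then, 1 heavy atom (1 iodine) and 6 heavy atoms in a six-membered aromatic ring of carbon only are not told apart by this read-out, so a substituent of quite different size can stand here with no step beyond the scatter in this pair. No measured property at hand bears on this step.

As far as these compounds go, it remains open whether this tolerance of change holds for groups of another kind at the same place, such as a carboxylic acid or a longer alkyl chain, since only iodo and phenyl can be compared here. Compound 3 differs from compound 1 in more than one place, so the contribution of the substituent's place on the ring cannot be read from these compounds as a single change.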